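The compounds below may be only part of what the source reports. "The series", "measured", "known", "first", "only" and "open" are said of these compounds alone.

Measured so far in a functional assay on HCT-116 cells (Homo sapiens) for antiproliferative activity, read by sulforhodamine B assay, with a stated time of 48 h; a higher number here means a weaker inhibitor, a lower number a stronger inhibitor:
- compound 1 `COc1cc(O)c(C(=O)/C=C/c2ccc(OC)c(OC)c2)c(OC)c1`: 27600 nM
- compound 2 `COc1cc(O)c(C(=O)/C=C/c2cc(Cl)cc(Cl)c2)c(OC)c1`: 1900 nM
- compound 3 `COc1ccc(/C=C/C(=O)c2c(OC)cc(OC)cc2OCC=C(C)C)cc1`: 7600 nM

In this set of three, compound 3 sits in the middle. Compound 1 has a higher number and compound 2 a lower one, and both gaps lie beyond the scatter of repeated measurements.

The next compound, compound 4 `COc1cc(/C=C/C(=O)c2c(OC)cc(OC)cc2OCC=C(C)C)cc(OC)c1`, differs from compound 3 in one place: 3,5-dimethoxyphenyl in place of 4-methoxyphenyl on a double-bonded chain carbon bound to a double-bonded chain carbon. Among the compounds with values here, no measured pair differs in one place only, so the data offer no direct guide to this swap. Within the data shown here, the values of compound 1 and compound 2 show only that numbers in this small set can spread widely, so the range has to stay broad. No shift beyond the scatter is expected in this assay, with a slight lean towards a lower number. The expected change is a 1.4-fold lower number from compound 3 to compound 4 (0.14 log units; within the scatter). For compound 4 the estimated value is 5500 nM, with an expected range from 2200 nM to 14000 nM.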

Compound 4, half-maximal inhibitory concentration: 3500 nM
The estimate for compound 4 lay 1.6-fold (0.20 log units) above the measured number; low and high end bracket the measured number.
By their numbers in this assay, from the lowest: compounds 2 and 4 (each within the scatter of the next); then compound 3; then compound 1.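

In this assay the swap of 4-methoxyphenyl for 3,5-dimethoxyphenyl on a double-bonded chain carbon bound to a double-bonded chain carbon gives a 2.2-fold lower number from compound 3 to compound 4 (0.34 log units; beyond the scatter) as a modest step. Within the data shown here, this is the first direct comparison at this position, and it shows that the aryl group here can change its methoxy pattern and gain a methoxy group without any loss of antiproliferative activity. Nothing available explains why the number falls.

This single step cannot separate the removal of the 4-methoxy group from the addition of the two new methoxy groups, and it comes from one shared core only. From the compounds shown here alone, how an aryl group carrying an amine or a carboxylic acid would behave at this position remains open.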